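Urea in place of chloroalkyl amide on the sulfonate core

The source may hold more compounds than are shown below. What is called first, only, known or untested is meant among the compounds shown, and "the series" means these compounds.

Working notes. In a functional assay on HT-29 cells (Homo sapiens) for antiproliferative activity, read by sulforhodamine B assay, with a stated time of 48 h (on this read-out higher numbers stand for weaker inhibition and lower numbers for stronger inhibition), compound 3 `O=C(CCCCl)Nc1ccc(S(=O)(=O)Oc2ccccc2I)cc1` gives 9100 nM, the second highest of three numbers; compound 1 `CCCCCC(=O)Nc1ccc(S(=O)(=O)Oc2ccccc2I)cc1` gives 13000 nM, within the scatter of compound 3, while compound 2 `O=C(CCl)Nc1ccc(S(=O)(=O)Oc2ccccc2I)cc1` gives 4100 nM, the lowest. Steps so far: a 3.2-fold lower number from compound 1 to compound 2 (0.50 log units; beyond the scatter), a 2.2-fold higher number from compound 2 to compound 3 (0.35 log units; beyond the scatter) and a 1.4-fold lower number from compound 1 to compound 3 (0.15 log units; within the scatter). Compound 4 `CCCCCNC(=O)Nc1ccc(S(=O)(=O)Oc2ccccc2I)cc1` differs from compound 3 by pentylamino in place of 3-chloropropyl on a carbonyl carbon. For the measured compounds named here, no measured step touches an amino group on the carbonyl; the chain changes seen are all modest, and the longest chain, compound 1 at 13000 nM, sits highest. Compound 4 is therefore expected to give about 11000 nM, range 3500 nM to 35000 nM, a step of a 1.2-fold higher number from compound 3 to compound 4 (0.08 log units; within the scatter), which is expected to stay near the scatter.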

Compound 4, half-maximal inhibitory concentration: 6600 nM
The estimate for compound 4 lay 1.7-fold (0.22 log units) above the measured number; the measured number falls inside the stated range.
By their numbers in this assay, from the lowest: compounds 2, 4, 3 and 1 (each within the scatter of the next, the first and the last beyond it).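

Pentylamino on the carbonyl carbon, the only urea shown, cannot be separated from any of the three amides in this assay: the steps read (a 1.4-fold lower number from compound 3 to compound 4 (0.14 log units; within the scatter)), (a 1.6-fold higher number from compound 2 to compound 4 (0.21 log units; within the scatter)) and (a 2.0-fold lower number from compound 1 to compound 4 (0.29 log units; within the scatter)), all within the scatter. An amino group on this carbonyl is therefore tolerated, and a chain without chlorine stays within the scatter of compound 2, unlike the pentyl of compound 1, whose step to compound 2 lies beyond it. Nothing available explains this result.

Open, as far as these compounds go, is whether a 2-chloroethylamino group on the same carbonyl would give a lower number than compound 2. Also open, from the compounds shown here alone, is how a shorter chain or a phenyl ring on the urea nitrogen would read.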